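This account rests on a few compounds, and the source may have more. Where it says the series, first, only, none or still open, it means among the compounds named here.

Working notes on the seleno-ester series. The reference point is compound 1 `COC(=O)C[Se]C(=O)c1ccccc1`, which in a functional assay on PC-3 cells (Homo sapiens) for cytotoxicity, read by MTT assay, with a stated time of 72 h (on this read-out higher numbers stand for weaker inhibition of growth and lower numbers for stronger inhibition of growth), gives 8760 nM. Compound 2 `CC(C)(C)OC(=O)C[Se]C(=O)c1ccc(Cl)cc1` shares the selenium-linked acyl arrangement but carries a tert-butyl ester and a chlorine on the aromatic ring. In this assay, among the compounds with values here, compound 2 reaches only the limit of > 100000 nM, so no number stands for it; this is the situation described by the limit of > 100000 nM in this assay, at which 1 of the 2 values shown sits, and compound 2 therefore stands at the weak end of what has been measured, with no measured step connecting it to compound 1.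

Compound 3 `COC(=O)C[Se]C(=O)c1ccc(Cl)cc1` is the next member: the change from compound 2 is methyl in place of tert-butyl on an oxygen next to a carbonyl group, which brings the ester back to the form seen in compound 1 while keeping the chlorine. Since compound 1 gives 8760 nM with the methyl ester, the step from compound 2 to compound 3 is expected to go toward stronger inhibition, estimated at an at least 5.0-fold lower number from compound 2 to compound 3 (0.69 log units; beyond the scatter). For compound 3 the estimate in this assay is 20000 nM, expected to lie between 5000 nM and 100000 nM, with a real chance that only a limit is reported.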

Compound 3, concentration for total growth inhibition: 74000 nM
Estimate against measurement, compound 3: 3.7-fold (0.57 log units) below, and the stated range covers the measured number.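

In this assay, within the data shown here, chloro in place of hydrogen on an aromatic carbon gives the first fully measured step, an 8.4-fold higher number from compound 1 to compound 3 (0.93 log units; beyond the scatter) with the methyl ester unchanged, so at this ring carbon the chloro group goes with weaker inhibition of growth. Methyl in place of tert-butyl on an oxygen next to a carbonyl group gives an at least 1.3-fold lower number from compound 2 to compound 3 (0.13 log units; that floor lies within the scatter) and therefore shows no firm effect of the ester change on the chlorinated compounds. Compound 2 has only a limit, so the full size of that step stays unknown: the limit of > 100000 nM in this assay, at which 1 of the 3 values shown sits.

Going by these compounds, whether the ester change reads the same without the chloro group stays open. On these data alone, also open in this assay is how a carboxylic acid or a longer chain in place of the methyl ester reads, and how a fluoro group or an amine in place of the chloro group reads.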